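A few compounds are considered here, and "the series" means these few. Any claim that something is new, unique, unknown or untested is made for them only; others in the source may bear on it.

Compound 1 `Cc1cn([C@@H]2O[C@H](CO[Si](C)(C)C(C)(C)C)[C@@]3(OS(=O)(=O)C=C3NC(=O)NC(=O)c3ccccc3)[C@H]2O[Si](C)(C)C(C)(C)C)c(=O)n(C)c1=O`: in an ADME assay on HEL cells (Homo sapiens) for cytotoxicity, with a stated time of 3 days (on this read-out higher numbers stand for lower toxicity in this test and lower numbers for higher toxicity in this test), compound 1 gives >= 80000 nM, a limit of the assay.
Compound 2 `Cc1cn([C@@H]2O[C@H](CO[Si](C)(C)C(C)(C)C)[C@@]3(OS(=O)(=O)C=C3NC(=O)NC(=O)c3ccccc3)[C@H]2O)c(=O)n(C)c1=O`: in this assay compound 2 gives > 100000 nM, a limit.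
Compound 3 `Cc1cn([C@@H]2O[C@H](COC(=O)c3ccccc3)[C@@]3(OS(=O)(=O)C=C3NC(=O)NC(=O)c3ccccc3)[C@H]2O[Si](C)(C)C(C)(C)C)c(=O)n(C)c1=O`: in this assay compound 3 gives >= 5000 nM, a limit.

Compound 1 stands only at a limit, (the limit of >= 80000 nM in this assay, at which 1 of the 3 values shown sits), and no number for it is known. The two measured steps, a step that the two limits leave unreadable from compound 1 to compound 2 and a step that the two limits leave unreadable from compound 1 to compound 3, are both left unreadable by the limits on either side, so none of them gives a readable size. Compound 4 `Cc1cn([C@@H]2O[C@H](CO[Si](C)(C)C(C)(C)C)[C@@]3(OS(=O)(=O)C=C3NC(=O)Nc3ccccc3)[C@H]2O[Si](C)(C)C(C)(C)C)c(=O)n(C)c1=O` differs from compound 1 by phenyl in place of benzoyl on an amide-type nitrogen. For the measured compounds named here, no measured step touches this position, and the three values give no readable step anywhere. Compound 4 is therefore expected to give 80000 nM, within 20000 nM to 200000 nM, most likely again as a limit; the step of a number no higher from compound 1 to compound 4 (the limit leaves the size open) is an expectation of no change beyond the scatter.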

Compound 4, minimum cytotoxic concentration: 1400 nM
Estimate against measurement, compound 4: 57-fold (1.76 log units) above, and the stated range ends above it.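

For the compounds shown here, this is the first readable step: in this assay, phenyl in place of benzoyl on the amide-type nitrogen gives an at least 57-fold lower number from compound 1 to compound 4 (1.75 log units; beyond the scatter), a move towards higher toxicity in this test. The other steps cannot be read, so this nitrogen is the only place with a measured effect. The step's size stays open on one side, since compound 1 stands at a limit: the limit of >= 80000 nM in this assay, at which 1 of the 4 values shown sits.

As far as these compounds go, whether benzyl or acetyl on this nitrogen reads like benzoyl or like phenyl stays open. So does whether the change carries over to compound 2 and compound 3, whose values are limits.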